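The source may hold more compounds than are shown below. What is called first, only, known or untested is meant among the compounds shown, and "the series" means these compounds.

Working notes on the series

The series shares one core carrying the same benzylic amine side chain; the point of variation is the group on an aromatic carbon of the six-membered ring. Three compounds have numbers in a physicochemical assay for solubility, read by LC-MS, in phosphate buffer, with a stated time of 24 h, at pH 7.4; a lower number here means a less soluble compound, a higher number a more soluble compound. Compound 1 `CN(c1ccn(C)n1)c1cnc(NCc2c(F)ccc3c2CCO3)c2cn[nH]c(=O)c12` gives 12000 nM in this assay. For the measured compounds named here, compound 2 `CNC(=O)c1cc(-c2cnc(NCc3c(F)ccc4c3CCO4)c3cn[nH]c(=O)c23)n(C)n1` gives 7000 nM in this assay, and the only single-point step so far, a 1.7-fold lower number from compound 1 to compound 2 (0.23 log units; within the scatter), sits within the scatter. Compound 3 `O=C1CCCN1c1cnc(NCc2c(F)ccc3c2CCO3)n2cnnc12` gives 640000 nM in this assay, the highest of the three numbers, a gap to compound 1 and to compound 2 that lies beyond the scatter in both cases.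

Compound 4 `CC1(C)CC(=O)N(c2cnc(NCc3c(F)ccc4c3CCO4)n3cnnc23)C1` is the next member: 4,4-dimethyl-2-oxopyrrolidin-1-yl in place of 2-oxopyrrolidin-1-yl on an aromatic carbon. Going by the values given here, no measured step covers a change of this kind; the one step available, from compound 1 to compound 2, concerns a different group and was within the scatter, so it gives no direct guidance on size or direction. With only this to go on, a modest step in this assay from compound 3 to compound 4 is expected, a 2.6-fold lower number from compound 3 to compound 4 (0.41 log units; beyond the scatter), with compound 4 staying well above compound 1 and compound 2. Compound 4 is therefore estimated at 250000 nM in this assay, with a range from 80000 nM to 640000 nM.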

Compound 4, solubility: 57000 nM
Beside the measured number, compound 4's estimate is 4.4-fold (0.64 log units) above it; measured number outside the range, below it.
By their numbers in this assay, from the lowest: compounds 2 and 1 (each within the scatter of the next); then compound 4; then compound 3.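

For the compounds shown here, replacing 2-oxopyrrolidin-1-yl with 4,4-dimethyl-2-oxopyrrolidin-1-yl on the aromatic carbon gives an 11-fold lower number from compound 3 to compound 4 (1.05 log units; beyond the scatter) in this assay, the first step between compounds differing in one place that lies beyond the scatter, so the number at this position can respond strongly to a change made on the lactam ring itself rather than only to a swap of the whole group. The change is a small one by what can be counted: the five-membered non-aromatic ring, the hydrogen-bond acceptor, the absence of donors and the absence of net charge all stay the same, while heavy atoms go from 6 to 8 and both of the added atoms are carbon. No measurement at hand bears on what lies behind this step.

On these data alone, it remains open whether a single methyl on the lactam ring would give a step of similar size, or whether a hydroxyl or an amine at the same ring carbon would move the number the other way. Also open, as far as these compounds go, is how a morpholine or an open-chain amide at this aromatic carbon would compare with compound 3 on the same core.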